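The source may hold more compounds than are shown below. What is called first, only, known or untested is meant among the compounds shown, and "the series" means these compounds.

In an assay for binding affinity to dual specificity mitogen-activated protein kinase kinase 4 (Homo sapiens), read by KINOMEscan, tested at 100 nM (on this read-out higher numbers stand for a weaker effect at the one concentration tested and lower numbers for a stronger effect), the three measured compounds stand as follows:

Compound 1, `CCCS(=O)(=O)Nc1ccc(F)c(C(=O)c2n[nH]c3ncc(-c4cccc(OC)c4)cc23)c1F`: 6.3%
Compound 2, `CCCS(=O)(=O)Nc1ccc(F)c(C(=O)c2n[nH]c3ncc(-c4ccccc4N)cc23)c1F`: 23%
Compound 3, `CCCS(=O)(=O)Nc1ccc(F)c(C(=O)c2n[nH]c3ncc(-c4cccc(N(C)C)c4)cc23)c1F`: 26%

Compound 3 carries the highest of the three numbers in this assay. Its nearest neighbour is compound 2, and the two are separated by a number 3 percentage points higher from compound 2 to compound 3 (within the scatter), which is within the scatter. Its furthest neighbour is compound 1, from which it is separated by a number 19.7 percentage points higher from compound 1 to compound 3 (beyond the scatter), a step beyond the scatter.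

Compound 4, `CCCS(=O)(=O)Nc1ccc(F)c(C(=O)c2n[nH]c3ncc(-c4ccc(C(F)(F)F)cc4)cc23)c1F`, is built from compound 3 by the change (4-(trifluoromethyl)phenyl in place of 3-(dimethylamino)phenyl on an aromatic carbon). Among the measured compounds shown here, none of the measured steps tests a trifluoromethyl group or a group on the position it occupies here; the steps of a number 16.7 percentage points higher from compound 1 to compound 2 (beyond the scatter) and a number 19.7 percentage points higher from compound 1 to compound 3 (beyond the scatter) only show that an exchange of the group on this phenyl ring can move the number in this assay by a modest amount, while a number 3 percentage points higher from compound 2 to compound 3 (within the scatter) shows that another such exchange moves it by nothing beyond the scatter. For the measured compounds named here, with no closer precedent, the expected step of a number 6 percentage points lower from compound 3 to compound 4 (within the scatter) is uncertain in direction and taken as small. Compound 4 is therefore estimated at 20%, within a range from 4% to 55%.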

Compound 4, a percentage reported as activity, at one concentration (the size of the read-out at that concentration, not a potency): 29%
Beside the measured number, compound 4's estimate is 9 percentage points below it; the measured number falls inside the stated range.
By their numbers in this assay, from the lowest: compound 1; then compounds 2, 3 and 4 (each within the scatter of the next).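

At this aromatic carbon of the shared core, in this assay, 4-(trifluoromethyl)phenyl stays level with the two nitrogen-bearing aryl groups, with the steps of a number 3 percentage points higher from compound 3 to compound 4 (within the scatter) and a number 6 percentage points higher from compound 2 to compound 4 (within the scatter). Compound 1 alone stands apart, with the step of a number 22.7 percentage points higher from compound 1 to compound 4 (beyond the scatter), so the three groups in compound 2, compound 3 and compound 4 now form one level despite their different substituents and ring positions, while 3-methoxyphenyl in compound 1 goes against that grouping. Nothing available here explains why these groups fall together or why compound 1 does not.

From the compounds shown here alone, it remains open whether the lower number of compound 1 belongs to the methoxy group or to its place on the ring, which 4-methoxyphenyl and 2-methoxyphenyl would test. Going by these compounds, it also remains open how 3-(trifluoromethyl)phenyl or 3-ethoxyphenyl would read at this position.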